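Shorter hydroxycarbamoyl chain in a series at its limit

This account rests on a few compounds, and the source may have more. Where it says the series, first, only, none or still open, it means among the compounds named here.

Compound 1 `Nc1nc2cc(-c3nn(CCCC(=O)NO)c4ncnc(N)c34)ccc2o1` is the starting point in a functional assay on CNE-2 cells (Homo sapiens) for inhibition, read by MTT assay, with a stated time of 72 h; a higher number here means a weaker inhibitor, a lower number a stronger inhibitor. In this assay compound 1 gives > 50000 nM, which is a limit of the assay and not a number. Compound 2 `Nc1ncnc2c1c(-c1cnc3[nH]ccc3c1)nn2CCCCCC(=O)NO` gives > 50000 nM, which is also a limit. Among the compounds with values here, the position of compound 1 is therefore known only through (the limit of > 50000 nM in this assay, at which 2 of the 2 values shown sit), and no measured step is available.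

Compound 3 `Nc1nc2cc(-c3nn(CCC(=O)NO)c4ncnc(N)c34)ccc2o1` differs from compound 1 in one place: hydroxycarbamoyl in place of (hydroxycarbamoyl)methyl on a saturated chain carbon, two bonds along the chain from an aromatic nitrogen. The same difference reads as 3-(hydroxycarbamoyl)propyl to 2-(hydroxycarbamoyl)ethyl. No shift beyond the scatter is expected in this assay, in either direction, and this expectation rests on (the limit of > 50000 nM in this assay, at which 2 of the 2 values shown sit). The estimated step of a number no higher from compound 1 to compound 3 (the limit leaves the size open) is expected to stay within the scatter. For compound 3 the estimated value is 50000 nM, with an expected range from 25000 nM to 100000 nM.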

Compound 3, half-maximal inhibitory concentration: > 150000 nM
Compound 3: a limit, no number (the forecaster's own chance of this, stated with the estimate: 85%); middle value at least 3.0-fold (0.47 log units) from the limit.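

In this assay, compound 3 gives > 150000 nM, a limit and not a number. Within the data shown here, compound 1 also stands at a limit, so no step between compound 1 and compound 3 can be read. The compounds shown leave open whether hydroxycarbamoyl chain length on the shared core affects inhibition at all.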